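The source may hold more compounds than are shown below. What is called first, only, known or untested is meant among the compounds shown, and "the series" means these compounds.

Measured so far in an ADME assay on HEp-2 cells (Homo sapiens) for cytotoxicity, read by MTT assay, with a stated time of 3 days; on this read-out lower numbers stand for higher toxicity in this test and higher numbers for lower toxicity in this test:

compound 1, `CCCC[C@H](CCn1cncn1)c1ccc(Cl)cc1`, 20.2 ug/mL
compound 2, `CCCC[C@H](CCn1cncn1)c1ccc(C)cc1`, 23.7 ug/mL
compound 3, `Clc1ccc([C@@H](CCn2cncn2)Cc2ccccc2)cc1`, 25.9 ug/mL

In this assay compound 1 gives 20.2 ug/mL, compound 2 gives 23.7 ug/mL and compound 3 gives 25.9 ug/mL. Compound 2 differs from compound 1 only by methyl in place of chloro on an aromatic carbon, and that change gave a 1.2-fold higher number from compound 1 to compound 2 (0.07 log units; within the scatter). Compound 3 differs from compound 1 by phenyl in place of propyl on a saturated chain carbon, two bonds along the chain from an aromatic carbon, with a 1.3-fold higher number from compound 1 to compound 3 (0.11 log units; within the scatter).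

Compound 4, `Cc1ccc([C@@H](CCn2cncn2)Cc2ccccc2)cc1`, has not yet been measured. It differs from compound 3 by methyl in place of chloro on an aromatic carbon, which is the same change, at the same place, that turned compound 1 into compound 2, here made on the core of compound 3. The earlier change gave a 1.2-fold higher number from compound 1 to compound 2 (0.07 log units; within the scatter), a small change at most, and the step from compound 3 to compound 4 is therefore expected to be similar. The expected step is a 1.2-fold higher number from compound 3 to compound 4 (0.06 log units; within the scatter), because compound 3 starts from 25.9 ug/mL and the earlier change hardly moved the number. For compound 4 the estimate is 30 ug/mL, with a likely range from 18 ug/mL to 50 ug/mL.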

Compound 4, half-maximal cytotoxic concentration: 83.3 ug/mL
For compound 4 the middle estimate is 2.8-fold (0.44 log units) below the measured one, outside the stated range (above it).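

In this assay, methyl in place of chloro barely moved the number on the core of compound 1, but on the core of compound 3 it gave a 3.2-fold higher number from compound 3 to compound 4 (0.51 log units; beyond the scatter), so the size of this step did not carry over from one core to the other: the same change on two cores in this assay, a 1.2-fold higher number (0.07 log units; within the scatter) from compound 1 to compound 2 and a 3.2-fold higher number (0.51 log units; beyond the scatter) from compound 3 to compound 4, 2.7-fold (0.44 log units) apart, beyond the scatter of two such steps

The phenyl-for-propyl change, read on the methyl-bearing core, gave a 3.5-fold higher number from compound 2 to compound 4 (0.55 log units; beyond the scatter), and it too differs from its earlier step: the same change on two cores in this assay, a 1.3-fold higher number (0.11 log units; within the scatter) from compound 1 to compound 3 and a 3.5-fold higher number (0.55 log units; beyond the scatter) from compound 2 to compound 4, 2.7-fold (0.44 log units) apart, beyond the scatter of two such steps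

Together these show that the two changes do not simply add up here, since methyl and phenyl together give a clearly higher number, meaning lower toxicity in this test, but with only one pair of cores they do not show why, or whether other cores would behave the same way.

Going by these compounds, it remains open whether the rise is specific to methyl or would also appear with a fluoro, a methoxy or an amine in the same place on the core of compound 3. On these data alone, it is also open whether a longer chain, such as hexyl, in place of the phenyl would give a similar result.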